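The source may report more compounds than this note shows. Statements on the series, on what has been measured and on what is new or still open speak of the compounds shown alone.

Measured in a functional assay on CaEs17 cells (Homo sapiens) for cytotoxicity, read by MTT assay, with a stated time of 72 h; a higher number here means a weaker inhibitor, a lower number a stronger inhibitor:
Compound 1 `C=C1C(=O)[C@@]23C(=O)OC[C@]4(C(=O)CCC(C)(C)[C@H]4C=O)[C@@H]2CC[C@@H]1[C@H]3OC(=O)c1ccccc1`: 1710 nM
Compound 2 `C=C1C(=O)[C@@]23C(=O)OC[C@]4(C(=O)CCC(C)(C)[C@H]4C=O)[C@@H]2CC[C@@H]1[C@H]3OC(=O)c1ccccc1F`: 8550 nM

Of the two, compound 2 has the higher number, 8550 nM, and is the weaker inhibitor. Compound 3 `C=C1C(=O)[C@@]23C(=O)OC[C@]4(C(=O)CCC(C)(C)[C@H]4C=O)[C@@H]2CC[C@@H]1[C@H]3OC(=O)c1ccc(Cl)cc1` differs from it by 4-chlorophenyl in place of 2-fluorophenyl on a carbonyl carbon, with 4-chlorophenyl in place of 2-fluorophenyl on a carbonyl carbon. Within the data shown here, the one measured step that bears on this is a 5.0-fold higher number from compound 1 to compound 2 (0.70 log units; beyond the scatter), a modest change with fluoro in place of hydrogen on an aromatic carbon. Among the measured compounds shown here, compound 3 lacks that fluoro, but no measured compound carries chlorine, so only a partial return towards compound 1 is expected in this assay. The expected step is a 2.7-fold lower number from compound 2 to compound 3 (0.43 log units; beyond the scatter). The estimate for compound 3 is 3200 nM, with an expected range of 1100 nM to 9500 nM.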

Compound 3, half-maximal inhibitory concentration: 2550 nM
For compound 3 the middle estimate is 1.3-fold (0.10 log units) above the measured one; measured number inside the range.
By their numbers in this assay, from the lowest: compounds 1 and 3 (each within the scatter of the next); then compound 2.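

Measured in this assay the change to 4-chlorophenyl gives a 3.4-fold lower number from compound 2 to compound 3 (0.53 log units; beyond the scatter) and so undoes the loss seen with 2-fluorophenyl. Set against hydrogen, chloro gives a 1.5-fold higher number from compound 1 to compound 3 (0.17 log units; within the scatter) and so this aromatic ring can carry a halogen without a readable change, though the step from compound 2 alters both the halogen and its place, leaving those two differences unseparated. Nothing measured here offers a reason for these differences.

On these data alone, whether 4-fluorophenyl or 2-chlorophenyl would match compound 2 or compound 3 stays open, as does the outcome with an amine or a carboxylic acid on this ring.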